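A few compounds are considered here, and "the series" means these few. Any claim that something is new, unique, unknown or untested is made for them only; others in the source may bear on it.

Measured compounds and their values:
compound 2, `CC1=CC[C@H](C(C)C)c2cc(C)c(OC(=O)c3ccc(C)cc3)cc21`, gives 67.7%;
compound 3, `CC1=CC[C@H](C(C)C)c2cc(C)c(OC(=O)c3ccc([N+](=O)[O-])cc3)cc21`, gives 16.8%;
compound 1, `COc1cccc(C(=O)Oc2cc3c(cc2C)[C@@H](C(C)C)CC=C3C)c1`, is reported as "not active" (no number reported).

All three were tested in a functional assay on U-251 cells (Homo sapiens) for antiproliferative activity, read by sulforhodamine B assay, with a stated time of 48 h, tested at 50 uM; on this read-out higher numbers stand for more inhibition at the one concentration tested (going by the name of the read-out) and lower numbers for less inhibition. Among the two compounds with a number, compound 3 stands lowest, and the gap to compound 2 is beyond the usual scatter; compound 1 has no number at all. The step being followed goes from compound 3 to compound 4, `CC1=CC[C@H](C(C)C)c2cc(C)c(OC(=O)c3ccccc3)cc21`, and the change is hydrogen in place of nitro on an aromatic carbon.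

Going by the values given here, one measured step bears on this change: a number 50.9 percentage points lower from compound 2 to compound 3 (beyond the scatter). That step put a nitro group where a methyl group had been, and the inhibition fell by a large amount. The step to compound 4 removes that same nitro group again, leaving only hydrogen in its place. Nothing measured shows directly how hydrogen compares with methyl at this position, so the expectation is that compound 4 moves back toward compound 2, though not necessarily all the way, with a step of about a number 28.2 percentage points higher from compound 3 to compound 4 (beyond the scatter) expected in this assay. Compound 4 is therefore estimated at 45%, with a range from 15% to 75%.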

Compound 4, a percentage reported as inhibition, at one concentration (the size of the read-out at that concentration, not a potency): 25.8%
Compound 4: middle estimate off by 19.2 percentage points, on the high side; the range from low to high includes it.
By their numbers in this assay, from the lowest: compounds 3 and 4 (each within the scatter of the next); then compound 2.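

Going from 4-nitrophenyl to phenyl gives a number 9 percentage points higher from compound 3 to compound 4 (within the scatter) in this assay, so at this aromatic carbon, nitro and hydrogen cannot be told apart on this read-out. Compound 2 is the one that stands apart, with a number 41.9 percentage points lower from compound 2 to compound 4 (beyond the scatter), which means the earlier drop cannot be read simply as harm done by the nitro group: the loss of methyl, with hydrogen in its place, goes with a large fall as well. No measurement shown here explains why methyl differs from the other two groups at this position.

Going by these compounds alone, with only three groups compared at this carbon, it stays open whether the higher inhibition is particular to methyl or would also appear with a longer chain such as ethyl, or with an amine or a carboxylic acid in the same place. Each of these numbers also comes from a single concentration, so the compounds shown leave open how the three would compare across a range of concentrations.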